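Fluoro in Place of Hydrogen on Compound 1

The source may report more compounds than this note shows. Statements on the series, on what has been measured and on what is new or still open speak of the compounds shown alone.

Compound 1 `O=C1CSC(N2N=C(c3ccc(Cl)c(Cl)c3)CC2c2ccccc2)=N1` was tested in an ADME assay on RAW264.7 cells (Mus musculus) for cytotoxicity, read by MTT assay, with a stated time of 24 h (on this read-out higher numbers stand for lower toxicity in this test and lower numbers for higher toxicity in this test), where compound 1 gives 295000 nM, the lowest of the two numbers available. Its nearest neighbour is compound 3 `Cc1ccc(C2=NN(C3=NC(=O)CS3)C(c3ccccc3C)C2)cc1C`, which in this assay gives 317000 nM. Compound 2 `Cc1ccc(C2=NN(C3=NC(=O)CS3)C(c3ccccc3)C2)cc1C` in this assay reaches only a limit of the assay, > 450000 nM. The measured step of an at least 1.5-fold higher number from compound 1 to compound 2 (0.18 log units; that floor lies within the scatter) exchanges one aryl ring, and the step of an at least 1.4-fold lower number from compound 2 to compound 3 (0.15 log units; that floor lies within the scatter) adds a methyl on an aromatic carbon; both floors lie within the scatter. Compound 4 `O=C1CSC(N2N=C(c3ccc(Cl)c(Cl)c3)CC2c2ccc(F)cc2)=N1` differs from compound 1 by fluoro in place of hydrogen on an aromatic carbon, phenyl to 4-fluorophenyl. Within the data shown here, no measured step covers fluoro, and the nearest one, the methyl step, stayed within the scatter, so no step beyond the scatter is expected in this assay. Compound 4 is therefore estimated at 300000 nM, between 150000 nM and 450000 nM, with an expected step of a 1.0-fold higher number from compound 1 to compound 4 (0.01 log units; within the scatter).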

Compound 4, half-maximal cytotoxic concentration: 139000 nM
Estimate against measurement, compound 4: 2.2-fold (0.33 log units) above; measured number below the stated range.
By their numbers in this assay, from the lowest: compound 4; then compounds 1 and 3 (each within the scatter of the next). At a limit, above all of these: compound 2.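

Going from phenyl to 4-fluorophenyl gives a 2.1-fold lower number from compound 1 to compound 4 (0.33 log units; beyond the scatter) in this assay and is the first one-place change shown whose size can be read as beyond the scatter. The earlier steps shown here reached only floors within it, whereas here a single added fluorine atom on this aromatic carbon moves the number toward higher toxicity in this test. Nothing measured here bears on why this happens.

Going by these compounds, whether this position responds only to fluoro remains open. Chloro, an amine or a carboxylic acid at the same place would help to settle that.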